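This account rests on a few compounds, and the source may have more. Where it says the series, first, only, none or still open, it means among the compounds named here.

Compound 1 `CCCCc1cn(C(c2ccccc2)c2cc3cc(Br)ccc3nc2OC)nn1` gives 11.1% in an ADME assay on SK-OV-3 cells (Homo sapiens) for cytotoxicity, read by sulforhodamine B assay, with a stated time of 48 h, tested at 10 uM; a lower number here means less inhibition, a higher number more inhibition at the concentration tested (going by the name of the read-out).
Compound 2 `COc1nc2ccc(Br)cc2cc1C(c1ccccc1)n1cc(-c2ccccc2F)nn1` gives 7.33% in this assay.
Compound 3 `COc1nc2ccc(Br)cc2cc1C(c1ccccc1)n1cc(CO)nn1` gives 3.23% in this assay.

The three numbers sit close together: a number 7.9 percentage points lower from compound 1 to compound 3 (within the scatter) and a number 4.1 percentage points lower from compound 2 to compound 3 (within the scatter), so compound 3 is not separated from the others. Compound 4 `COc1nc2ccc(Br)cc2cc1C(c1ccccc1)n1cc(C2CC2)nn1` differs from compound 3 by cyclopropyl in place of hydroxymethyl on an aromatic carbon. The same ring carbon was varied in every measured step: a number 3.8 percentage points lower from compound 1 to compound 2 (within the scatter), a number 7.9 percentage points lower from compound 1 to compound 3 (within the scatter) and a number 4.1 percentage points lower from compound 2 to compound 3 (within the scatter), each within the scatter. Swapping groups here has therefore not moved this assay beyond the scatter, and no step beyond it is expected for compound 4 either. Compound 4 is expected to give 7%, between 0% and 16%, meaning an estimated a number 3.8 percentage points higher from compound 3 to compound 4 (within the scatter).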

Compound 4, a percentage reported as inhibition, at one concentration (the size of the read-out at that concentration, not a potency): 3.52%
The estimate for compound 4 lay 3.5 percentage points above the measured number; the measured number falls inside the stated range.
By their numbers in this assay, from the lowest: compounds 3, 4, 2 and 1 (each within the scatter of the next).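

Swapping hydroxymethyl for cyclopropyl removes the hydrogen-bond donor and acceptor of that group and brings in a three-membered carbon ring, yet a number 0.3 percentage points higher from compound 3 to compound 4 (within the scatter) in this assay. The cyclopropyl group is also not separated from the other two groups at this aromatic carbon, with a number 3.8 percentage points lower from compound 2 to compound 4 (within the scatter) and a number 7.6 percentage points lower from compound 1 to compound 4 (within the scatter) in the same assay. No measured evidence is available to explain this flat result. Going by these compounds, it remains open whether an amine or a carboxylic acid at this position, or a change elsewhere on the shared core, would move the number beyond the scatter.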